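Dropping a Methyl Group: Expected Growth Inhibition of Compound 4

This account rests on a few compounds, and the source may have more. Where it says the series, first, only, none or still open, it means among the compounds named here.

Compound 1, `Cc1ccccc1Nc1nc(Nc2ccccc2)ncc1Cl`: in an ADME assay on L02 cells (Homo sapiens) for inhibition, read by CCK-8 assay, with a stated time of 48 h (on this read-out lower numbers stand for stronger inhibition of growth and higher numbers for weaker inhibition of growth), compound 1 gives > 100000 nM, a limit of the assay.
Compound 2, `Cc1ccc(Nc2ncc(Cl)c(Nc3ccccc3C)n2)cc1`: in this assay compound 2 gives > 100000 nM, a limit of the assay.
Compound 3, `Cc1ccccc1Nc1nc(Nc2ccc(N3CCN(C)CC3)cn2)ncc1Cl`: in this assay compound 3 gives 5980 nM.

Among the compounds with values here, compound 3 is the only one with a number; the other two sit at the limit of > 100000 nM in this assay, at which 2 of the 3 values shown sit. The change from compound 2 to compound 1 is hydrogen in place of methyl on an aromatic carbon, and its step, a step that the two limits leave unreadable from compound 2 to compound 1, cannot be sized. The difference between the cores of compound 3 and compound 2 is not broken down here.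

Compound 4, `CN1CCN(c2ccc(Nc3ncc(Cl)c(Nc4ccccc4)n3)nc2)CC1`, is not yet measured. It differs from compound 3 by hydrogen in place of methyl on an aromatic carbon. The place differs from the earlier change, where the methyl was para to a large group rather than ortho to a large group, so this is the same kind of change, not the same one. Because the measured step that the two limits leave unreadable from compound 2 to compound 1 is unreadable, the expectation rests on compound 3 alone: only a single carbon leaves, so compound 4 is expected to stay close, an estimated step of a 1.2-fold higher number from compound 3 to compound 4 (0.07 log units; within the scatter). Compound 4 is expected to give about 7000 nM, between 2500 nM and 25000 nM.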

Compound 4, concentration for 50% growth inhibition: 7990 nM
For compound 4 the middle estimate is 1.1-fold (0.06 log units) below the measured one; measured number inside the range.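

In this assay, exchanging 2-methylphenyl for phenyl on the core of compound 3 gives a 1.3-fold higher number from compound 3 to compound 4 (0.13 log units; within the scatter), so on this core the read-out does not separate the two compounds. This is a single readable step, so it shows that the methyl group can leave one core without a measurable difference, not that the same holds on other cores in the series. The earlier hydrogen-for-methyl change, which sits at a different place on a different core, offers no size to set beside it, because compound 1 and compound 2 each give a limit of the assay and not a number: the limit of > 100000 nM in this assay, at which 2 of the 4 values shown sit.

The compounds shown leave open whether another group at the place of the methyl, such as a methoxy group, an ethyl group or a fluorine atom, would also leave the number within the scatter. They also leave open which part of the difference between the core of compound 3 and the core of compound 2 goes with compound 3 having a readable number at all.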